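From methylsulfanyl to azido: what to expect for compound 4

The compounds below may be only part of what the source reports. "The series", "measured", "known", "first", "only" and "open" are said of these compounds alone.

Measured so far in an ADME assay on L6 cells (Rattus norvegicus) for inhibition, read by resazurin assay, with a stated time of 72 h; on this read-out lower numbers stand for stronger inhibition and higher numbers for weaker inhibition:
- compound 1 `CSC[C@H]1O[C@@H](n2cnc3c(N)nc(F)nc32)[C@H](OC(C)=O)[C@@H]1OC(C)=O`: 15000 nM
- compound 2 `CSC[C@H]1O[C@@H](n2cnc3c(N)nc(Cl)nc32)[C@H](OC(C)=O)[C@@H]1OC(C)=O`: 216000 nM
- compound 3 `C[S+]([O-])C[C@H]1O[C@@H](n2cnc3c(N)nc(F)nc32)[C@H](O)[C@@H]1O`: 13000 nM

Compound 1 sits at the low end of this small set. It lies within the scatter of compound 3, while compound 2 reads far higher. Compound 4 `CC(=O)O[C@@H]1[C@H](OC(C)=O)[C@@H](CN=[N+]=[N-])O[C@H]1n1cnc2c(N)nc(F)nc21` has not yet been measured in this assay. It keeps the core of compound 1 and changes one group: azido in place of methylsulfanyl on a saturated chain carbon bound to a saturated ring carbon. Azido takes the place of methylsulfanyl on a saturated chain carbon bound to a saturated ring carbon.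

For the measured compounds named here, only one measured step compares compounds that differ in a single place: a 14-fold higher number from compound 1 to compound 2 (1.16 log units; beyond the scatter). That step is large, but it is chloro in place of fluoro on an aromatic carbon, not the place changed here, so it gives no direction for compound 4. Compound 1 and compound 3 differ in more than one place, yet compound 3 gives 13000 nM, within the scatter of compound 1. Going by the values given here, no measured step tests the azido swap directly, so no step beyond the scatter is expected, with a wide margin either way. The expected step is a 1.1-fold higher number from compound 1 to compound 4 (0.03 log units; within the scatter). For compound 4 the estimated value is 16000 nM, with an expected range from 4000 nM to 80000 nM.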

Compound 4, half-maximal inhibitory concentration: 18000 nM
Compound 4: the middle estimate sits 1.1-fold (0.05 log units) below what was measured; low and high end bracket the measured number.
By their numbers in this assay, from the lowest: compounds 3, 1 and 4 (each within the scatter of the next); then compound 2.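

In this assay, azido in place of methylsulfanyl on a saturated chain carbon bound to a saturated ring carbon gives a 1.2-fold higher number from compound 1 to compound 4 (0.08 log units; within the scatter) and so stays within the usual scatter of repeated measurements. For the compounds shown here, this is the first single-place comparison at this position, and it shows that a sulfur-containing group and an all-nitrogen group can be exchanged here without a change this read-out can distinguish, unlike the large step on the aromatic carbon (a 14-fold higher number from compound 1 to compound 2 (1.16 log units; beyond the scatter)). The information shown offers no measured explanation for why the methylsulfanyl and azido compounds read alike.

The compounds shown leave open whether an amine, a carboxylic acid or a longer chain at this same place would also stay within the scatter of compound 1, or would instead shift the number as strongly as the chloro swap did. They also leave open whether the azido group would behave the same way on a different core, such as one carrying chloro instead of fluoro.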